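A few compounds are considered here, and "the series" means these few. Any claim that something is new, unique, unknown or untested is made for them only; others in the source may bear on it.

Measured so far:
- compound 1, `O=c1[nH]c(=O)n([C@H]2C[C@H](O)[C@@H](CO)O2)cc1-c1cn(-c2c(F)cccc2F)nn1`: >= 10000 nM
- compound 2, `O=c1[nH]c(=O)n([C@H]2C[C@H](O)[C@@H](CO)O2)cc1-c1cn(-c2cc(F)cc(F)c2)nn1`: 220000 nM
- compound 3, `CC(C)(C)c1ccc(-n2cc(-c3cn([C@H]4C[C@H](O)[C@@H](CO)O4)c(=O)[nH]c3=O)nn2)cc1`: 230000 nM

All three share one core and differ only in the aromatic group on the ring nitrogen. In an ADME assay on HEL cells (Homo sapiens) for cytotoxicity, read by cell counting, with a stated time of 3 days (a lower number here means that less compound is tolerated, a higher number that more compound is tolerated), compound 1 gives only a limit, >= 10000 nM, not a number. In this assay compound 2 gives 220000 nM and compound 3 gives 230000 nM, so compound 3 carries the highest of the two numbers, with compound 2 nearest: a 1.0-fold higher number from compound 2 to compound 3 (0.02 log units; within the scatter).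

The unmeasured compound 4, `CCCCc1ccc(-n2cc(-c3cn([C@H]4C[C@H](O)[C@@H](CO)O4)c(=O)[nH]c3=O)nn2)cc1`, differs from compound 3 in one place: butyl in place of tert-butyl on an aromatic carbon.

Which measured steps bear on this? The steps from compound 1 are unreadable because of the limit of >= 10000 nM in this assay, at which 1 of the 3 values shown sits. For the measured compounds named here, the only readable step, a 1.0-fold higher number from compound 2 to compound 3 (0.02 log units; within the scatter), swaps one aromatic group for another and stays within the scatter. Going by the values given here, no measured step changes a tert-butyl to a butyl, so the expectation rests on the observation that the two readable numbers sit together. No step beyond the scatter is therefore expected in this assay.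

Compound 4 is expected to give 200000 nM, with a range from 80000 nM to 450000 nM. That expectation corresponds to a 1.2-fold lower number from compound 3 to compound 4 (0.06 log units; within the scatter).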

Compound 4, minimum cytotoxic concentration: 230000 nM
Estimate against measurement, compound 4: 1.2-fold (0.06 log units) below; measured number inside the range.
By their numbers in this assay, from the lowest: compounds 2, 3 and 4 (each within the scatter of the next).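

In this assay, putting butyl in place of tert-butyl, which keeps the same atoms but joins them differently, gives no change at the digits printed from compound 3 to compound 4 (within the scatter) on this aromatic carbon. The earlier readable step only exchanged one aromatic group for another on the ring nitrogen, and the new exchange of 3,5-difluorophenyl for 4-butylphenyl gives a 1.0-fold higher number from compound 2 to compound 4 (0.02 log units; within the scatter), so compound 2, compound 3 and compound 4 all sit within the scatter of one another. The steps from compound 1 cannot be read: the limit of >= 10000 nM in this assay, at which 1 of the 4 values shown sits.

Going by these compounds, whether a longer chain than butyl at this position would stay with these numbers remains open. So does the outcome for an amine or a carboxylic acid on this aromatic carbon.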